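The source may report more compounds than this note shows. Statements on the series, on what has been measured and on what is new or still open speak of the compounds shown alone.

Measured compounds in a functional assay on HeLa cells (Homo sapiens) for inhibition, read by sulforhodamine B assay, with a stated time of 48 h; on this read-out lower numbers stand for stronger inhibition of growth and higher numbers for weaker inhibition of growth:
compound 1, `COC(=O)[C@@]1(C)CCC=C2[C@@H]1CC[C@@H](C)[C@]2(C)Cc1c[nH]c2c(C)cccc12`, gives 4900 nM
compound 2, `COC(=O)[C@@]1(C)CCC=C2[C@@H]1CC[C@@H](C)[C@]2(C)Cc1c[nH]c2c(Br)cccc12`, gives 13000 nM
compound 3, `COC(=O)[C@@]1(C)CCC=C2[C@@H]1CC[C@@H](C)[C@]2(C)Cc1c(C)[nH]c2ccc(C)cc12`, gives 17000 nM

Compound 1 and compound 2 share one core and differ by bromo in place of methyl on an aromatic carbon; in this assay that change gave a 2.7-fold higher number from compound 1 to compound 2 (0.42 log units; beyond the scatter). Compound 3 and compound 4, `COC(=O)[C@@]1(C)CCC=C2[C@@H]1CC[C@@H](C)[C@]2(C)Cc1c(C)[nH]c2ccc(Br)cc12`, differ by bromo in place of methyl on an aromatic carbon. This is the same kind of change as the first, though the place is not the same word for word: in compound 2 the bromo sits ortho to a fused ring and meta to a fused ring, in compound 4 it sits meta to a fused ring and para to a fused ring. The difference between the core of compound 1 and the core of compound 3 is not broken down here. Compound 3 lies within the scatter of compound 2 and beyond it from compound 1.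

With a single earlier case of this exchange, the step from compound 3 to compound 4 is expected to be of similar size, a 2.1-fold higher number from compound 3 to compound 4 (0.31 log units; beyond the scatter), because the earlier bromo for methyl exchange gave a 2.7-fold higher number from compound 1 to compound 2 (0.42 log units; beyond the scatter). Compound 4 is therefore expected to give about 35000 nM in this assay, most likely between 15000 nM and 90000 nM.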

Compound 4, concentration for 50% growth inhibition: 11000 nM
Compound 4: the middle estimate sits 3.2-fold (0.50 log units) above what was measured, outside the stated range (below it).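

In this assay, bromo in place of methyl on an aromatic carbon gave a 1.5-fold lower number from compound 3 to compound 4 (0.19 log units; within the scatter), so on this core the exchange leaves no difference that can be told from the scatter. Set beside the earlier step, the same exchange does not carry over from one core to the other in this series: the same change on two cores in this assay, a 2.7-fold higher number (0.42 log units; beyond the scatter) from compound 1 to compound 2 and a 1.5-fold lower number (0.19 log units; within the scatter) from compound 3 to compound 4, 4.1-fold (0.61 log units) apart, beyond the scatter of two such steps. This shows that the size and direction of the step read on the core of compound 1 cannot be applied as they stand to the core of compound 3, but it does not show what separates the two steps, as the pairs differ both in core and in the place of the exchange.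

The compounds shown leave open whether the exchange keeps its size when made at one and the same place on both cores. They also leave open whether a different group on this aromatic carbon, such as an amine or a carboxylic acid, would move the number beyond the scatter.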